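Replacing a chlorothiophene with a phenoxy group

The source may hold more compounds than are shown below. What is called first, only, known or untested is meant among the compounds shown, and "the series" means these compounds.

The shared core is seen in compound 1 `CCOC(=O)c1cnc(C)nc1NN1C(=O)C=C(C)C1=O` and compound 2 `CCOC(=O)c1cnc(-c2ccc(Cl)s2)nc1NN1C(=O)C=C(C)C1=O`. In a functional assay on Jurkat cells for inhibition of nuclear factor NF-kappa-B complex (Homo sapiens) (a lower number here means a stronger inhibitor, a higher number a weaker inhibitor), compound 1 gives 16000 nM, while compound 2 gives 300 nM. For the measured compounds named here, compound 2 stands at the lowest of the two numbers measured so far, and the single step between the two, a 53-fold lower number from compound 1 to compound 2 (1.73 log units; beyond the scatter), shows that the aromatic carbon between the two ring nitrogen atoms is a place where a change moves the read-out strongly.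

Compound 3 `CCOC(=O)c1cnc(Oc2ccccc2)nc1NN1C(=O)C=C(C)C1=O` differs from compound 2 in one place: phenoxy in place of 5-chlorothiophen-2-yl on an aromatic carbon. Going by the values given here, no measured pair covers this exact exchange. The step from compound 1 to compound 2 bears on it only in showing how much this position matters; it does not tell whether a phenoxy group behaves more like the methyl of compound 1 or like the 5-chlorothiophen-2-yl of compound 2. Compound 3 is therefore expected to land between those two, as a step of a 6.7-fold higher number from compound 2 to compound 3 (0.82 log units; beyond the scatter), with wide uncertainty. The estimate for compound 3 in this assay is 2000 nM, within a range from 400 nM to 10000 nM.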

Compound 3, half-maximal inhibitory concentration: 15000 nM
Beside the measured number, compound 3's estimate is 7.5-fold (0.88 log units) below it; measured number outside the range, above it.
By their numbers in this assay, from the lowest: compound 2; then compounds 3 and 1 (each within the scatter of the next).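

In this assay the exchange of 5-chlorothiophen-2-yl for phenoxy gives a 50-fold higher number from compound 2 to compound 3 (1.70 log units; beyond the scatter) and so removes the whole of the gain that compound 2 held over compound 1. Against the methyl group, the same phenoxy group gives a 1.1-fold lower number from compound 1 to compound 3 (0.03 log units; within the scatter) and leaves no difference that can be read, so at this aromatic carbon, between the two ring nitrogen atoms, a large group with an aromatic ring does not by itself bring the low number of compound 2. Among these three compounds, only the 5-chlorothiophen-2-yl group stands apart, and no measurement at hand explains why.

The exchange changes several things at once: the oxygen link, the five-membered ring with its sulfur, and the chlorine, so the three compounds cannot say which of these carries the difference. Going by these compounds, a phenyl group joined directly to the carbon, an unsubstituted thiophen-2-yl group and a 4-chlorophenyl group would each separate part of this, and how any of them would read in this assay remains open.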